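A few compounds are considered here, and "the series" means these few. Any claim that something is new, unique, unknown or untested is made for them only; others in the source may bear on it.

Of the compounds shown here, three built on a shared core have been tested in a functional assay on the whole organism with Rattus norvegicus as the target; a higher number here means that more compound is needed for the effect, a lower number that less compound is needed. Compound 1 `CCCc1ccc2nc(N)sc2c1` gives 6 mg/kg. Compound 2 `Nc1nc2ccc(C(F)(F)C(F)(F)F)cc2s1` gives 2.5 mg/kg. Compound 3 `CCCn1c(=N)sc2cc(OC(F)(F)F)ccc21` gives 4.5 mg/kg, the second highest of the three numbers; its nearest neighbour is compound 1 and its furthest is compound 2, yet both gaps lie within the scatter, so the three cannot be told apart on these results. Compound 4 `C[S+]([O-])CCn1c(=N)sc2cc(OC(F)(F)F)ccc21` differs from compound 3 by a group of 3 heavy atoms (1 carbon, 1 oxygen, 1 sulfur; no ring) in place of one carbon atom, on a saturated chain carbon, two bonds along the chain from an aromatic nitrogen. Within the data shown here, no pair of measured compounds that differ in one place is at hand, so the size of this step must be estimated. a 1.3-fold higher number from compound 3 to compound 4 (0.12 log units; within the scatter) is expected to stay within the scatter. Compound 4 is expected to give about 6 mg/kg, somewhere between 2.5 mg/kg and 15 mg/kg.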

Compound 4, dose for half-maximal effect: 1.1 mg/kg
Compound 4: the middle estimate sits 5.5-fold (0.74 log units) above what was measured, outside the stated range (below it).
By their numbers in this assay, from the lowest: compound 4; then compounds 2, 3 and 1 (each within the scatter of the next, the first and the last beyond it).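

At this place, on a saturated chain carbon, two bonds along the chain from an aromatic nitrogen, the chain is not a neutral spot: swapping the methyl for a group of 3 heavy atoms holding sulfur and oxygen gives a 4.1-fold lower number from compound 3 to compound 4 (0.61 log units; beyond the scatter) and so a change larger than the usual scatter. Among these compounds, this single step is the first comparison in which only one place differs. Nothing measured here accounts for the change.

Going by these compounds, whether a thioether without the oxygen, an alcohol or a carboxylic acid at this place would lower the number as well remains open.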